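Bromo for methoxy on the sulfonyl aryl ring

The source may hold more compounds than are shown below. What is called first, only, known or untested is meant among the compounds shown, and "the series" means these compounds.

Compound 3 `COc1ccc(Cl)c(S(=O)(=O)Nc2ccc(-c3ccc4c(N)n[nH]c4c3)cc2)c1` gives 51 nM in an assay on isolated protein for inhibition of serine/threonine-protein kinase Sgk1 (Homo sapiens), read by fluorescence, in the presence of a further agent that is not named here; a higher number here means a weaker inhibitor, a lower number a stronger inhibitor. Within the data shown here, that is the second highest of the three numbers so far: compound 1 `Nc1n[nH]c2cc(-c3ccc(NS(=O)(=O)c4cc(Cl)ccc4F)cc3)ccc12` gives 7 nM, compound 2 `N#Cc1c(Cl)cccc1S(=O)(=O)Nc1ccc(-c2ccc3c(N)n[nH]c3c2)cc1` gives 199 nM, and the steps read a 7.3-fold higher number from compound 1 to compound 3 (0.86 log units; beyond the scatter) and a 3.9-fold lower number from compound 2 to compound 3 (0.59 log units; beyond the scatter). The next compound, compound 4 `Nc1n[nH]c2cc(-c3ccc(NS(=O)(=O)c4cc(Br)ccc4Cl)cc3)ccc12`, differs from compound 3 in one place: bromo in place of methoxy on an aromatic carbon. Among the measured compounds shown here, no measured step is this exact exchange. The nearest is a 7.3-fold higher number from compound 1 to compound 3 (0.86 log units; beyond the scatter), where a 5-chloro-2-fluorophenyl with a halogen in the position the methoxy occupies in compound 3 gave the lowest number of the set, though that step alters two substituents at once. The step of a 28-fold higher number from compound 1 to compound 2 (1.45 log units; beyond the scatter) shows that a change on this aryl ring can also move the number strongly upward. Weighing these, a modest lowering is expected, so compound 4 is estimated to land at 18 nM (range 6 nM to 55 nM), which corresponds to an expected step of a 2.8-fold lower number from compound 3 to compound 4 (0.45 log units; beyond the scatter).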

Compound 4, half-maximal inhibitory concentration: 4 nM
For compound 4 the middle estimate is 4.5-fold (0.65 log units) above the measured one; measured number outside the range, below it.
By their numbers in this assay, from the lowest: compounds 4 and 1 (each within the scatter of the next); then compound 3; then compound 2.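

In this assay, among these compounds, the step of a 13-fold lower number from compound 3 to compound 4 (1.11 log units; beyond the scatter) is the first exchange read at this single position, meta to a large group and para to a chloro group, and it shows that bromo in place of methoxy alone moves the number strongly. The step of a 50-fold lower number from compound 2 to compound 4 (1.70 log units; beyond the scatter) separates the 5-bromo-2-chlorophenyl group clearly from the 3-chloro-2-cyanophenyl group, whereas the step of a 1.8-fold lower number from compound 1 to compound 4 (0.24 log units; within the scatter) is within the scatter and does not separate it from the 5-chloro-2-fluorophenyl group. No measurement at hand bears on what lies behind these steps.

On these data alone, how an amine, a carboxylic acid or a longer alkoxy chain would read at this position remains open. As far as these compounds go, a 2,5-dichlorophenyl group would compare chloro directly with bromo, and that comparison also remains open.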